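From nitro to cyano: compound 3 to compound 4

A few compounds are considered here, and "the series" means these few. Any claim that something is new, unique, unknown or untested is made for them only; others in the source may bear on it.

In a functional assay on QGY-7703 cells (Homo sapiens) for cytotoxicity, read by MTT assay, with a stated time of 24 h (a higher number here means a weaker inhibitor, a lower number a stronger inhibitor), compound 1 `CN1C/C(=C\c2cccnc2)C(=O)/C(=C/c2cc([N+](=O)[O-])ccc2F)C1` gives 11100 nM, compound 2 `O=C1/C(=C/c2cccnc2)CN(S(=O)(=O)c2ccc([N+](=O)[O-])cc2)C/C1=C\c1ccccc1F` gives 5600 nM and compound 3 `O=C1/C(=C/c2ccncc2)CN(S(=O)(=O)c2ccc([N+](=O)[O-])cc2)C/C1=C\c1ccccc1F` gives 8800 nM. Compound 3 lies within the scatter of both other compounds, so it holds no distinct rank among them.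

Compound 4 `N#Cc1ccc(S(=O)(=O)N2C/C(=C\c3ccncc3)C(=O)/C(=C/c3ccccc3F)C2)cc1` keeps the structure of compound 3 except for one change: cyano in place of nitro on an aromatic carbon, para to a large group (cyano in place of nitro on an aromatic carbon). Among the compounds with values here, the only measured step, a 1.6-fold higher number from compound 2 to compound 3 (0.20 log units; within the scatter), exchanges pyridin-3-yl for pyridin-4-yl and stays within the scatter. Within the data shown here, it bears on the new change only indirectly, since no measured pair covers nitro and cyano. With no direct evidence on this change, the anchor is compound 3 at 8800 nM, and no shift beyond the scatter is expected in this assay. The expected move is a 1.0-fold higher number from compound 3 to compound 4 (0.01 log units; within the scatter). For compound 4, the estimated value is 9000 nM, with an expected range of 4000 nM to 20000 nM.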

Compound 4, half-maximal inhibitory concentration: 8500 nM
For compound 4 the middle estimate is 1.1-fold (0.02 log units) above the measured one; low and high end bracket the measured number.
By their numbers in this assay, from the lowest: compounds 2, 4, 3 and 1 (each within the scatter of the next).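

In this assay, the nitro-to-cyano exchange on the aromatic carbon para to a large group gives a 1.0-fold lower number from compound 3 to compound 4 (0.02 log units; within the scatter). Within the data shown here, this is the first reading of any change at this position; the earlier step touched only the pyridine attachment, whereas this one alters the sulfonyl-bearing aryl group. For this pair, 4-cyanophenyl reads the same as 4-nitrophenyl within the scatter, so the nitro group is not needed to hold this level of cytotoxicity, and nothing measured on either group accompanies the result.

Still open, going by these compounds, is whether a group of another kind at this position, such as an amine or a carboxylic acid, would hold the same level. Also open, on these data alone, is whether cyano reads alike with pyridin-3-yl, as carried by compound 2, given that cyano appears here only with pyridin-4-yl.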